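Extending the Chain Once More

This account rests on a few compounds, and the source may have more. Where it says the series, first, only, none or still open, it means among the compounds named here.

In a functional assay on HepG2 cells (Homo sapiens) for inhibition, read by MTT assay, with a stated time of 72 h (a lower number here means a stronger inhibitor, a higher number a weaker inhibitor), compound 1 `Nc1nc2cc(-c3nn(CCC(=O)NO)c4ncnc(N)c34)ccc2o1` gives only a limit, > 150000 nM. Going by the values given here, compound 2 `Nc1nc2cc(-c3nn(CCCCCC(=O)NO)c4ncnc(N)c34)ccc2o1` gives 1990 nM, the only actual number so far. Compound 3 `Nc1nc2cc(-c3nn(CCCCCCCCC(=O)NO)c4ncnc(N)c34)ccc2o1` has not yet been measured. It repeats the same extension further along the chain, with 3-(hydroxycarbamoyl)propyl in place of hydroxycarbamoyl on a saturated chain carbon, five bonds along the chain from an aromatic nitrogen. Among the compounds with values here, the one measured step that bears on this is the same exchange made two bonds along the chain from an aromatic nitrogen, an at least 75-fold lower number from compound 1 to compound 2 (1.87 log units; beyond the scatter), which is large. A single step cannot show how far lengthening keeps lowering the number. A further but much smaller fall is therefore expected, and no real change remains possible, with an expected 2.0-fold lower number from compound 2 to compound 3 (0.30 log units; within the scatter). For compound 3 the estimate is 1000 nM, with an expected range of 250 nM to 5000 nM.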

Compound 3, half-maximal inhibitory concentration: 2610 nM
For compound 3 the middle estimate is 2.6-fold (0.42 log units) below the measured one; the measured number falls inside the stated range.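

In this assay, the further extension gives a 1.3-fold higher number from compound 2 to compound 3 (0.12 log units; within the scatter), so at this position the large effect of the first extension does not carry on with more chain. The longer chain still keeps what the short chain lacks, with an at least 57-fold lower number from compound 1 to compound 3 (1.75 log units; beyond the scatter). Compound 1 gives a limit and not a number, so the true size of this step stays unknown: the limit of > 150000 nM in this assay, at which 1 of the 3 values shown sits.

The compounds shown leave open how a chain longer than in compound 1 but shorter than in compound 2 would behave, and whether a chain longer than in compound 3 would stay at this level. They also leave open whether the hydroxycarbamoyl end itself is required, which a carboxylic acid in its place could test.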